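The source may report more compounds than this note shows. Statements on the series, on what has been measured and on what is new or still open speak of the compounds shown alone.

Working notes on the series

Compound 1 `N=C(NCCCc1c[nH]cn1)NCCC(c1ccccc1)c1ccccn1` is the reference point. Going by the values given here, in a functional assay on cardiac atrium for agonist activity at histamine H2 receptor (Cavia porcellus) (on this read-out lower numbers stand for lower potency and higher numbers for higher potency (the scale is a negative logarithm)), compound 1 gives 7.39, the higher of the two numbers measured so far. Its nearest neighbour is compound 2 `N=C(NCCCc1c[nH]cn1)NCCCC(c1ccccc1)c1ccccn1`, in which the chain between the guanidine and the branching carbon is one unit longer; in this assay compound 2 gives 6.61, a number that lies beyond the scatter below that of compound 1. Among the compounds with values here, no single-point step between measured compounds exists, so no measured pair guides the next change.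

Compound 3 `N=C(NCCCc1c[nH]cn1)NCCC(c1ccc(Br)cc1)c1ccccn1` differs from compound 1 by bromo in place of hydrogen on an aromatic carbon, the phenyl becoming 4-bromophenyl, on a position para to a large group. Within the data shown here, no measured analogue carries a substituent on this ring. The step is expected to be small, if anything a slight loss, with a number 0.19 log units lower from compound 1 to compound 3 (within the scatter) the expected size in this assay. For compound 3 the estimated value is 7.2, with a range from 6.5 to 7.9.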

Compound 3, negative logarithm of the half-maximal effective concentration: 7.48
For compound 3 the middle estimate is 0.28 log units below the measured one, within the range that was stated.
By their numbers in this assay, from the lowest: compound 2; then compounds 1 and 3 (each within the scatter of the next).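

Bromo in place of hydrogen on this aromatic carbon, para to a large group, gives a number 0.09 log units higher from compound 1 to compound 3 (within the scatter) in this assay, so compound 1 and compound 3 cannot be told apart on this read-out. The earlier compounds shown here carried no substituent on this ring; the result shows that the position accepts a single bromine atom and that the 4-bromophenyl analogue keeps a number in the same range as the phenyl compound. Nothing at hand bears on why the read-out stays level with this change.

Open, as far as these compounds go, is whether a fluoro, a methoxy group or an amine on the same carbon would read the same way. Also open, from the compounds shown here alone, is whether bromo on the longer chain of compound 2 would give a similar step.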